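The source may hold more compounds than are shown below. What is called first, only, known or untested is meant among the compounds shown, and "the series" means these compounds.

Compound 1 `CN(C)C1(Cc2ccccc2)CCN(c2cc(C(F)(F)F)ccc2CNC(=O)Nc2ccc(CNS(C)(=O)=O)c(F)c2)CC1`: 16.4 nM
Compound 2 `CN(C)C1(Cc2ccccc2)CCN(c2cc(C(F)(F)F)ccc2CNC(=O)Nc2cccc3ccc(O)cc23)CC1`: 0.46 nM
Compound 3 `CN(C)C1(Cc2ccccc2)CCN(c2cc(C(F)(F)F)ccc2CNC(=O)Nc2cccc3[nH]c(=O)ccc23)CC1`: 1.67 nM

In an assay on CHO cells for displacement of a labelled ligand from transient receptor potential cation channel subfamily V member 1 (Homo sapiens), read by scintillation counting, with a stated time of 60 min (a lower number here means a stronger inhibitor, a higher number a weaker inhibitor), compound 3 holds the second highest of the three numbers: compound 2 sits lower, compound 1 higher, and both gaps lie beyond the scatter. Compound 4 `CN(C)C1(Cc2ccccc2)CCN(c2cc(C(F)(F)F)ccc2CNC(=O)Nc2cccc3ccncc23)CC1` has not yet been measured in this assay. It differs from compound 3 in one place: a group of 10 heavy atoms (9 carbon, 1 nitrogen; one six-membered aromatic ring of carbon only, one six-membered aromatic ring with 1 hetero atom) in place of a group of 11 heavy atoms (9 carbon, 1 nitrogen, 1 oxygen; one six-membered aromatic ring of carbon only, one six-membered aromatic ring with 1 hetero atom), on an amide-type nitrogen. The group that enters carries no hydrogen-bond donor, whereas the group that leaves carried one together with an oxygen.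

Within the data shown here, only one measured step bears on this place, the exchange of one group on the amide-type nitrogen for another, which gave a 3.6-fold higher number from compound 2 to compound 3 (0.56 log units; beyond the scatter). Among the measured compounds shown here, both groups in that step contained an oxygen, so no measured pair tells what removing the oxygen and the donor does. Because the swap giving a 3.6-fold higher number from compound 2 to compound 3 (0.56 log units; beyond the scatter) was modest, a step of similar or smaller size is expected here, most likely toward a higher number, though a result within the scatter cannot be ruled out. The step from compound 3 to compound 4 is therefore expected to be a 1.7-fold higher number from compound 3 to compound 4 (0.22 log units; within the scatter). Compound 4 is estimated at 2.8 nM, within a range from 0.8 nM to 9 nM.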

Compound 4, inhibition constant: 12.3 nM
For compound 4 the middle estimate is 4.4-fold (0.64 log units) below the measured one; measured number above the stated range.
By their numbers in this assay, from the lowest: compound 2; then compound 3; then compounds 4 and 1 (each within the scatter of the next).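

Within this assay, this change shows that the group on the amide-type nitrogen can be exchanged for a close relative only at a clear cost: isoquinolin-8-yl gives a 7.4-fold higher number from compound 3 to compound 4 (0.87 log units; beyond the scatter), and measured against 7-hydroxynaphthalen-1-yl it gives a 27-fold higher number from compound 2 to compound 4 (1.43 log units; beyond the scatter), the first large step at this place. The two groups that hold both an oxygen and a hydrogen-bond donor, in compound 2 and compound 3, give lower numbers than isoquinolin-8-yl, which has no donor, whereas compound 1 goes against this pattern: its group on that nitrogen also holds oxygen, yet its number lies within the scatter of that of compound 4. No measurement given here explains why the number rises with this change.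

The compounds shown do not separate the loss of the oxygen from the loss of the donor, since these two go together in the step to isoquinolin-8-yl. Going by these compounds, it remains open whether a hydroxyl or an amine added to isoquinolin-8-yl would bring the number back toward those of compound 2 and compound 3, and whether a methoxy group could stand in for the hydroxyl of 7-hydroxynaphthalen-1-yl.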